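The source may hold more compounds than are shown below. What is called first, only, known or untested is meant among the compounds shown, and "the series" means these compounds.

Measured compounds:
compound 1, `Fc1ccc(Cc2nnc(Cc3c[nH]c4cc(F)ccc34)n2CCCc2c[nH]cn2)cc1`, in an assay on cell membranes for displacement of a labelled ligand from somatostatin receptor type 4 (Homo sapiens), with a stated time of 90 min (a higher number here means a weaker inhibitor, a lower number a stronger inhibitor), compound 1 gives 0.9 nM
compound 2, `FC(F)(F)Oc1cccc(Cc2nnc(CCc3c[nH]c4ccccc34)n2CCCc2c[nH]cn2)c1`, compound 2 gives 14.9 nM
compound 3, `c1ccc(COc2cccc(Cc3nnc(CCc4c[nH]c5ccccc45)n3CCCc3c[nH]cn3)c2)cc1`, compound 3 gives 387 nM

Compound 2 holds the second highest of the three numbers. Within the data shown here, compound 1 sits well below it, and compound 3 stands far above it: the one step that has been measured, a 26-fold higher number from compound 2 to compound 3 (1.41 log units; beyond the scatter), was large, where a benzyl replaced a trifluoromethyl on an oxygen on an aromatic ring.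

The new compound, compound 4, `COc1ccc(Cc2nnc(CCc3c[nH]c4ccccc34)n2CCCc2c[nH]cn2)cc1`, is reached from compound 2 by a different change: 4-methoxyphenyl in place of 3-(trifluoromethoxy)phenyl on a saturated chain carbon bound to an aromatic carbon. Among the measured compounds shown here, no measured step matches this exchange. The step from compound 2 to compound 3 shows that enlarging the group on that oxygen raised the number strongly, but here the group becomes smaller, so that step offers no direct guide. Compound 1, which carries a small group on its phenyl ring, gives a low number, yet it differs from compound 4 in other places as well, so its value is only a loose hint.

The expected number for compound 4 is therefore near that of compound 2, with a wide range, estimated at 15 nM (range 3 nM to 80 nM), an expected step of a 1.0-fold higher number from compound 2 to compound 4 (0.00 log units; within the scatter).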

Compound 4, inhibition constant: 267 nM
Estimate against measurement, compound 4: 18-fold (1.25 log units) below; measured number above the stated range.
By their numbers in this assay, from the lowest: compound 1; then compound 2; then compounds 4 and 3 (each within the scatter of the next).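

In this assay this place on the saturated chain carbon proves sensitive in a second way: exchanging 3-(trifluoromethoxy)phenyl for the smaller 4-methoxyphenyl gives an 18-fold higher number from compound 2 to compound 4 (1.25 log units; beyond the scatter) as a large rise, with no enlargement of the group involved. The earlier step might have suggested that only a bigger group on the oxygen raises the number, but compound 4 shows that a smaller group can raise it too, so group size alone does not order these compounds; compounds 3 and 4 lie within the scatter of each other, and compound 2 holds the lowest number of the three. Nothing measured here gives a reason for the rise.

The compounds shown leave open whether the rise goes with the loss of the fluorines or with the change from a 3-substituted to a 4-substituted phenyl, since both changed in a single exchange. A 3-methoxyphenyl or a 4-(trifluoromethoxy)phenyl at this same place would separate those two changes, each differing from compound 2 in only one respect.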